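Adding chloro to the anilino group of compound 3

The compounds below may be only part of what the source reports. "The series", "measured", "known", "first", "only" and "open" are said of these compounds alone.

Measured in a functional assay on A-375 cells (Homo sapiens) for antiproliferative activity, read by CCK-8 assay, with a stated time of 72 h; a lower number here means a stronger inhibitor, a higher number a weaker inhibitor:
- compound 1 `CCC(C)n1cnc2c(NCc3ccc(C(=O)Nc4ccccc4N)cc3)nc(Cl)nc21`: 2880 nM
- compound 2 `Nc1ccccc1NC(=O)c1ccc(COCNc2nc(Nc3ccccc3)c3ncn(C4CCCC4)c3n2)cc1`: 8700 nM
- compound 3 `CCCCn1cnc2c(Nc3ccccc3)nc(NCOCc3ccc(C(=O)Nc4ccccc4N)cc3)nc21`: 4480 nM

Compound 3, at 4480 nM, lies within the scatter of both compound 1 and compound 2, so the three-member set gives it no clear rank.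

Compound 4 `CCCCn1cnc2c(Nc3cccc(Cl)c3)nc(NCOCc3ccc(C(=O)Nc4ccccc4N)cc3)nc21` differs from compound 3 by chloro in place of hydrogen on an aromatic carbon, which turns the anilino group into (3-chlorophenyl)amino. For the measured compounds named here, the data contain no measured pair with this change. Going by the values given here, the one measured step, a 1.9-fold lower number from compound 2 to compound 3 (0.29 log units; within the scatter), is butyl in place of cyclopentyl on an aromatic nitrogen. It lies elsewhere in the structure and within the scatter, so it offers only weak guidance and no direction for a chloro change.

In this assay, no step beyond the scatter is therefore expected. The expected step is a 1.3-fold lower number from compound 3 to compound 4 (0.11 log units; within the scatter), a small change with an uncertain direction. For compound 4 the estimated value is 3500 nM, with an expected range of 1500 nM to 8000 nM.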

Compound 4, half-maximal inhibitory concentration: 6820 nM
Compound 4: the middle estimate sits 1.9-fold (0.29 log units) below what was measured; low and high end bracket the measured number.
By their numbers in this assay, from the lowest: compounds 1, 3, 4 and 2 (each within the scatter of the next, the first and the last beyond it).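

In this assay chloro in place of hydrogen, which turns the anilino group into (3-chlorophenyl)amino, gives a 1.5-fold higher number from compound 3 to compound 4 (0.18 log units; within the scatter) and is the only step shown on this ring. An aromatic carbon meta to a large group therefore carries a chlorine without a step beyond the scatter, and this single change sets no direction for the position. No measured property of these compounds bears on the result.

The compounds shown leave open whether a methoxy group, an amine or a carboxylic acid at this carbon, or chloro elsewhere on the ring, would give a step beyond the scatter. Also open, going by these compounds, is whether the same chloro change would read alike with cyclopentyl in place of butyl on the aromatic nitrogen, as in compound 2.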